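The source may hold more compounds than are shown below. What is called first, only, known or untested is meant among the compounds shown, and "the series" means these compounds.

Measured compounds in this study:

Compound 1 `Cc1nc(N)c2c(-c3cccs3)cn([C@@H]3O[C@H](CO)[C@@H](O)[C@H]3O)c2n1` — in a functional assay on K562 cells (Homo sapiens), read by MTT assay, with a stated time of 72 h (a lower number here means a stronger inhibitor, a higher number a weaker inhibitor), compound 1 is reported only as a limit, > 20000 nM.
Compound 2 `COc1nc(N)nc2c1c(-c1cccs1)cn2[C@@H]1O[C@H](CO)[C@@H](O)[C@H]1O` — in this assay compound 2 is likewise reported only as a limit, > 20000 nM.
Compound 3 `C#Cc1cn([C@@H]2O[C@H](CO)[C@@H](O)[C@H]2O)c2nc(C)nc(N)c12` — in this assay compound 3 gives 3290 nM.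

Compound 1 and compound 3 differ in one place: ethynyl in place of thiophen-2-yl on an aromatic carbon. That change brings the step of an at least 6.0-fold lower number from compound 1 to compound 3 (0.78 log units; beyond the scatter). Its size cannot be pinned down more closely because of the limit of > 20000 nM in this assay, at which 2 of the 3 values shown sit; only the starting point is a limit, so the true step may be larger than the stated figure.

Compound 2 shares with compound 1 the thiophen-2-yl group and the sugar, but the difference between the two cores is not broken down here.

The unmeasured compound 4 `C#Cc1cn([C@@H]2O[C@H](CO)[C@@H](O)[C@H]2O)c2nc(N)nc(OC)c12` stands to compound 2 as compound 3 stands to compound 1: ethynyl in place of thiophen-2-yl on an aromatic carbon. The place of the change is described in the same words for both pairs, so this is the same change on a different core.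

From compound 2 to compound 4 a step of about an at least 2.5-fold lower number from compound 2 to compound 4 (0.39 log units; beyond the scatter) is expected, resting on the step of an at least 6.0-fold lower number from compound 1 to compound 3 (0.78 log units; beyond the scatter) seen with the same change on the core of compound 1. Since compound 2 itself is known only as a limit, compound 4 may also end up at a limit rather than at a number. The estimate for compound 4 in this assay is 8000 nM, with a plausible range from 2000 nM to 30000 nM.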

Compound 4, half-maximal inhibitory concentration: > 20000 nM
Compound 4 gave a limit, no number; the forecaster's own chance of this, stated with the estimate: 35%; at least 2.5-fold (0.39 log units) between middle value and limit.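

No step can be read from compound 2 to compound 4, where ethynyl takes the place of thiophen-2-yl, because both results are limits and not numbers: the limit of > 20000 nM in this assay, at which 3 of the 4 values shown sit. The compounds shown leave open whether this change lowers the number on the core of compound 2, as it does on the core of compound 1, and by how much.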